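This account rests on a few compounds, and the source may have more. Where it says the series, first, only, none or still open, it means among the compounds named here.

Measured so far:
Compound 1 `NC(=O)c1c(NC(=O)c2ccccc2Cl)sc2c1CCN(C(=O)Nc1ccccc1Cl)C2`: 45400 nM
Compound 2 `CSc1ccccc1NC(=S)N1CCc2c(sc(NC(=O)c3ccccc3Cl)c2C(N)=O)C1`: 43600 nM

Both compounds were tested in a functional assay on HeLa cells (Homo sapiens) for antiproliferative activity, with a stated time of 24 h; a lower number here means a stronger inhibitor, a higher number a weaker inhibitor. Compound 2 `CSc1ccccc1NC(=S)N1CCc2c(sc(NC(=O)c3ccccc3Cl)c2C(N)=O)C1` gives 43600 nM there, and compound 1 gives 45400 nM; the two numbers sit within the scatter of each other, so neither can be called the stronger. Compound 3 `NC(=O)c1c(NC(=O)c2ccccc2Cl)sc2c1CCN(C(=O)Nc1c(Cl)cccc1Cl)C2` has not yet been measured. It differs from compound 2 at the amine nitrogen in the six-membered non-aromatic ring: a group of 11 heavy atoms (7 carbon, 1 nitrogen, 1 oxygen, 2 chlorine; one six-membered aromatic ring of carbon only) in place of a group of 11 heavy atoms (8 carbon, 1 nitrogen, 2 sulfur; one six-membered aromatic ring of carbon only), on an amine nitrogen in a ring. Within the data shown here, the one measured step that touches this same position, a 1.0-fold lower number from compound 1 to compound 2 (0.02 log units; within the scatter), swapped a carbamoyl-type group bearing one chlorine for the sulfur-containing group and left the number essentially unchanged. Returning to a carbamoyl group, now with two chlorines, is therefore expected to give no step beyond the scatter, a 1.0-fold higher number from compound 2 to compound 3 (0.01 log units; within the scatter). Compound 3 is estimated at 45000 nM, with a plausible range from 20000 nM to 100000 nM.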

Compound 3, half-maximal inhibitory concentration: 27200 nM
Compound 3: middle estimate off by 1.7-fold (0.22 log units), on the high side; measured number inside the range.
By their numbers in this assay, from the lowest: compounds 3, 2 and 1 (each within the scatter of the next).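

In this assay, the amine nitrogen in the ring has now carried a third group, (2,6-dichlorophenyl)carbamoyl, and the swap still stays within the scatter, at a 1.6-fold lower number from compound 2 to compound 3 (0.20 log units; within the scatter) for this change. Among these compounds, the result also adds the first single-atom comparison on this group: chloro in place of hydrogen on an aromatic carbon gives a 1.7-fold lower number from compound 1 to compound 3 (0.22 log units; within the scatter) and also stays within the scatter, so compounds 1, 2 and 3 cannot be ranked. No supporting measurement is available to explain how closely these numbers agree.

All three groups at this position carry a chlorinated or sulfur-bearing benzene ring, so the compounds shown leave open what a small acetyl or methyl group there would do. They also leave open whether an amine or a carboxylic acid on that aromatic ring would move the number beyond the scatter.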